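The compounds below may be only part of what the source reports. "The series", "measured", "known", "first", "only" and "open" are said of these compounds alone.

Compound 1 `Cc1cc(OCc2nc3ccccc3s2)ccc1NC(=O)Nc1ccccc1Cl`: 830 nM
Compound 2 `Cc1cc(OCc2nc3ccccc3s2)ccc1NC(=O)Nc1ccc(Cl)cc1`: 570 nM
Compound 3 `Cc1cc(NC(=O)Nc2ccc(Cl)c(Cl)c2)ccc1OCc1nc2ccccc2s1`: 2170 nM

In an assay on isolated protein for inhibition of Polyunsaturated fatty acid 5-lipoxygenase (Homo sapiens), read by HPLC, with a stated time of 10 min (on this read-out higher numbers stand for weaker inhibition and lower numbers for stronger inhibition), compound 3 gives 2170 nM, the highest of the three numbers; the nearest to it is compound 1, and the gap to compound 1 and the wider gap to compound 2 both lie beyond the scatter. Compound 4 `Cc1cc(NC(=O)Nc2ccc(Cl)cc2)ccc1OCc1nc2ccccc2s1` keeps the core of compound 3 and differs from it by hydrogen in place of chloro on an aromatic carbon. Among the compounds with values here, the only measured step, a 1.5-fold lower number from compound 1 to compound 2 (0.16 log units; within the scatter), moves the chloro group around the ring on the same amide-type nitrogen and stays within the scatter; no measured pair removes a chloro group, so it bears on the present change only loosely. Compound 2 carries the same 4-chlorophenyl group that compound 4 would carry, but on a different arrangement of the shared core, so its value can only hint. Compound 4 is therefore expected to give a lower number than compound 3, estimated at 1100 nM (range 400 nM to 3200 nM), that is, a step of a 2.0-fold lower number from compound 3 to compound 4 (0.30 log units; within the scatter).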

Compound 4, half-maximal inhibitory concentration: > 10000 nM
Compound 4: only a limit was reported (the forecaster's own chance of this, stated with the estimate: 5%); middle value at least 9.0-fold (0.95 log units) from the limit.
By their numbers in this assay, from the lowest: compounds 2 and 1 (each within the scatter of the next); then compound 3. At a limit, above all of these: compound 4.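

In this assay, going from 3,4-dichlorophenyl to 4-chlorophenyl gives an at least 4.6-fold higher number from compound 3 to compound 4 (0.66 log units; beyond the scatter), so on this arrangement of the core, the chloro group on this aromatic carbon, ortho to a chloro group and meta to a large group, goes with stronger inhibition than hydrogen does. Within the data shown here, the earlier compounds did not show this, since their only step, a 1.5-fold lower number from compound 1 to compound 2 (0.16 log units; within the scatter), moves a chloro group around the ring and stays within the scatter. The reading for compound 4, > 10000 nM, is a limit and not a number, so the step has a lower bound but no known full size: the limit of > 10000 nM in this assay, at which 1 of the 4 values shown sits.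

The compounds shown leave open whether a fluoro, methyl or methoxy group on this carbon would behave like the chloro group or like hydrogen. They also leave open what this core gives with a single chloro group on this carbon and hydrogen in place of the 4-chloro group.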